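A few compounds are considered here, and "the series" means these few. Any claim that something is new, unique, unknown or untested is made for them only; others in the source may bear on it.

Compound 1 `CCc1ccccc1NS(=O)(=O)c1cccc(NC(=O)NCCCCl)c1`: 43000 nM
Compound 2 `CCNC(=O)Nc1cccc(S(=O)(=O)Nc2ccccc2C)c1`: 108000 nM

In a functional assay on MCF7 cells (Homo sapiens) for cytotoxicity, read by sulforhodamine B assay, with a stated time of 48 h (on this read-out lower numbers stand for stronger inhibition and higher numbers for weaker inhibition), compound 2 stands at the higher of the two numbers, and compound 1 sits below it by a gap beyond the usual scatter. Compound 3 `CCNC(=O)Nc1cccc(S(=O)(=O)Nc2ccccc2CC)c1` differs from compound 2 by methyl in place of hydrogen on a saturated chain carbon bound to an aromatic carbon. Within the data shown here, since no measured pair shows this change, the expectation rests on nothing more than the change being small: a step from compound 2 to compound 3 of a 1.3-fold lower number from compound 2 to compound 3 (0.10 log units; within the scatter) is expected, which stays within the scatter. Compound 3 is therefore estimated at 85000 nM, with a range from 30000 nM to 250000 nM.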

Compound 3, half-maximal inhibitory concentration: 48000 nM
For compound 3 the middle estimate is 1.8-fold (0.25 log units) above the measured one; low and high end bracket the measured number.
By their numbers in this assay, from the lowest: compounds 1 and 3 (each within the scatter of the next); then compound 2.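

In this assay the change from 2-methylphenyl to 2-ethylphenyl gives a 2.3-fold lower number from compound 2 to compound 3 (0.35 log units; beyond the scatter) and so shows that this single added carbon matters, if only modestly. Hydrogen in place of chloromethyl on the saturated chain carbon, two bonds along the chain from an amide-type nitrogen, gives a 1.1-fold higher number from compound 1 to compound 3 (0.05 log units; within the scatter) and so leaves no difference that can be read at that place. Nothing available here explains either result. Going by these compounds, whether a longer chain such as propyl would lower the number further remains open, as does the effect of an amine or a carboxylic acid at the same place.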